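The source may report more compounds than this note shows. Statements on the series, on what has been measured and on what is new or still open speak of the compounds shown alone.

Measured in a functional assay on K562 cells (Homo sapiens) for inhibition, read by sulforhodamine B assay, with a stated time of 48 h; a lower number here means a stronger inhibitor of growth, a higher number a weaker inhibitor of growth:
- compound 1 `COc1cccc(C(=O)NNC(=O)c2ccc3[nH]c(-c4ccc([N+](=O)[O-])o4)nc3c2)c1`: 15.6 ug/mL
- compound 2 `O=C(NNC(=O)c1ccc2[nH]c(-c3ccc([N+](=O)[O-])o3)nc2c1)c1cccc(Oc2ccccc2)c1`: > 7.8 ug/mL (a limit, not a number)
- compound 3 `COc1ccc(C(=O)NNC(=O)c2ccc3[nH]c(-c4ccc([N+](=O)[O-])o4)nc3c2)cc1OC`: 15.6 ug/mL

Compound 1 stands level with compound 3 in this assay, with no change at the digits printed from compound 1 to compound 3 (within the scatter). Compound 2 has only a limit, so its place relative to compound 1 cannot be told, and the record shows a step that the limit leaves unreadable from compound 1 to compound 2.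

Compound 4 `COc1cccc(C(=O)NNC(=O)c2ccc3[nH]c(-c4ccc([N+](=O)[O-])s4)nc3c2)c1` keeps the rest of compound 1 and changes one group: 5-nitrothiophen-2-yl in place of 5-nitrofuran-2-yl on an aromatic carbon. The new group, 5-nitrothiophen-2-yl, stands in place of 5-nitrofuran-2-yl on an aromatic carbon between two ring nitrogen atoms.

Going by the values given here, no measured step touches this group, since compounds 1, 2 and 3 all carry 5-nitrofuran-2-yl. The two measured steps change the other end of the molecule, and only one of them can be read, namely no change at the digits printed from compound 1 to compound 3 (within the scatter). They offer indirect guidance at best, and the size of the exchange itself has not been measured. With no evidence for a direction, the expected result is no change at the digits printed from compound 1 to compound 4 (within the scatter) in this assay, with no shift beyond the scatter. Compound 4 is estimated at 15.6 ug/mL, with an expected range from 6 ug/mL to 40 ug/mL.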

Compound 4, concentration for 50% growth inhibition: 15.6 ug/mL
Beside the measured number, compound 4's estimate shows no gap at the digits printed; measured number inside the range.
By their numbers in this assay, from the lowest: compounds 1, 3 and 4 (each within the scatter of the next).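

In this assay, placing 5-nitrothiophen-2-yl in the position held by 5-nitrofuran-2-yl gives no change at the digits printed from compound 1 to compound 4 (within the scatter). Going by these compounds alone, this is the first reading at this aromatic carbon between two ring nitrogen atoms, as compounds 1, 2 and 3 all carry 5-nitrofuran-2-yl and their steps change only the other end of the molecule. It shows that, with the rest of compound 1 kept, a sulfur can stand in place of the oxygen in this five-membered aromatic ring without a shift beyond the scatter, though nothing measured here bears on why the two groups read alike.

From the compounds shown here alone, compound 2 gives > 7.8 ug/mL, which is a limit and not a number, so its step cannot be read and the effect of phenyl on that oxygen remains unknown. Also open, going by these compounds, are whether the reading at this position would hold with a 5-aminothiophen-2-yl group or an unsubstituted thiophen-2-yl group, and whether 5-nitrothiophen-2-yl would read the same alongside the second methoxy group of compound 3.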